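A few compounds are considered here, and "the series" means these few. Any claim that something is new, unique, unknown or untested is made for them only; others in the source may bear on it.

Compound 1 `O=C(CSC(=S)N[C@H]1CCOC1=O)Nc1ccc(Cl)cc1` was tested in a functional assay on MGC-803 cells (Homo sapiens) for cytotoxicity, read by MTT assay, with a stated time of 72 h (a higher number here means a weaker inhibitor, a lower number a stronger inhibitor), and gave 76900 nM, the highest of the two numbers obtained. Compound 3 `O=C(CCl)Nc1ccc(C(=O)/C=C/c2ccc(Br)cc2)cc1` gave 6050 nM in this assay, a lower number, and the gap between them lies beyond the usual scatter. For compound 2 `CCCCSC(=S)N[C@H]1CCOC1=O` this assay returned only a limit, > 128000 nM; this is the limit of > 128000 nM in this assay, at which 1 of the 3 values shown sits, and not a measured number.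

Compound 4 `O=C(CSC(=S)N[C@H]1CCOC1=O)Nc1ccc(C(=O)/C=C/c2ccccc2)cc1` has not yet been measured. It differs from compound 1 in one place: (2-phenylethenyl)carbonyl in place of chloro on an aromatic carbon. Going by the values given here, the entering group is the one carried by compound 3, whose value 6050 nM sits well below that of compound 1, so a step down, estimated as an 8.5-fold lower number from compound 1 to compound 4 (0.93 log units; beyond the scatter), is expected. For compound 4 the estimated value in this assay is 9000 nM, within a range of 2500 nM to 35000 nM.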

Compound 4, half-maximal inhibitory concentration: 24800 nM
Compound 4: middle estimate off by 2.8-fold (0.44 log units), on the low side; the range from low to high includes it.
By their numbers in this assay, from the lowest: compound 3; then compound 4; then compound 1. At a limit, above all of these: compound 2.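

Putting (2-phenylethenyl)carbonyl in place of chloro on this aromatic carbon, para to a large group, gives in this assay a 3.1-fold lower number from compound 1 to compound 4 (0.49 log units; beyond the scatter). Going by these compounds alone, this is the first single-place step, and it shows that the position tolerates a much larger group carrying an extra aromatic ring, with a modest gain. Nothing measured here accounts for that gain.

Which part of the entering group matters, the ring, the double bonds or the carbonyl, stays open. So does the effect of an amine or a carboxylic acid at this position.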